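Ester chain variation on a glycosylated core series

A few compounds are considered here, and "the series" means these few. Any claim that something is new, unique, unknown or untested is made for them only; others in the source may bear on it.

Compound 1 `C#CCOC(=O)C[C@@H]1C(C(=O)OC)=CO[C@@H](O[C@@H]2O[C@H](COC(C)=O)[C@@H](OC(C)=O)[C@H](OC(C)=O)[C@H]2OC(C)=O)/C1=C/C`: in a functional assay on SK-BR-3 cells (Homo sapiens) for antiproliferative activity, read by MTT assay, with a stated time of 72 h (on this read-out higher numbers stand for weaker inhibition and lower numbers for stronger inhibition), compound 1 reaches only the assay limit, > 15000 nM.
Compound 2 `C/C=C1/[C@H](O[C@@H]2O[C@H](COC(C)=O)[C@@H](OC(C)=O)[C@H](OC(C)=O)[C@H]2OC(C)=O)OC=C(C(=O)OC)[C@H]1CC(=O)OCCC1CCCCC1`: in this assay compound 2 likewise reaches only the assay limit, > 15000 nM.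

Compound 2 thus stands at the limit of > 15000 nM in this assay, at which 2 of the 2 values shown sit, with no number to place it. Among the compounds with values here, the single measured step, a step that the two limits leave unreadable from compound 1 to compound 2, has no readable size and sets no expectation. Compound 3 `C/C=C1/[C@H](O[C@@H]2O[C@H](COC(C)=O)[C@@H](OC(C)=O)[C@H](OC(C)=O)[C@H]2OC(C)=O)OC=C(C(=O)OC)[C@H]1CC(=O)OCCC(C)C` carries isopropyl in place of cyclohexyl on a saturated chain carbon, two bonds along the chain from an oxygen next to a carbonyl group. Within the data shown here, with both measured values limits and the one step unreadable, no step beyond the scatter can be projected. Compound 3 is expected to remain at the limit, the step being a step that the limit leaves unreadable from compound 2 to compound 3. Compound 3 is estimated at 20000 nM, range 8000 nM to 60000 nM.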

Compound 3, half-maximal inhibitory concentration: > 15000 nM
Compound 3: a limit, no number; the forecaster's own chance of this, stated with the estimate: 85%; the middle value does not contradict the limit.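

No step can be read among compound 1, compound 2 and compound 3, since each value is a limit and not a number: the limit of > 15000 nM in this assay, at which 3 of the 3 values shown sit.

The compounds shown leave open whether any ester chain on the shared core gives a measurable value.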